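The source may report more compounds than this note shows. Statements on the series, on what has been measured and on what is new or still open speak of the compounds shown alone.

Going by the values given here, compound 2 `COc1cc(-c2cc(/C=C/C(=O)c3ccc(Cl)c(Cl)c3)[nH]n2)cc(OC)c1OC` is, of the two compounds measured so far, the one with the highest number in a functional assay on NCI/ADR-RES cells (Homo sapiens) for inhibition, read by sulforhodamine B assay, with a stated time of 48 h (a lower number here means a stronger inhibitor of growth, a higher number a weaker inhibitor of growth), where compound 2 gives 10600 nM. Among the compounds with values here, its nearest neighbour is compound 1 `COc1cc(-c2cc(/C=C/C(=O)c3ccc(N)cc3)[nH]n2)cc(OC)c1OC`, which in this assay gives 3800 nM; the only step recorded, a 2.8-fold higher number from compound 1 to compound 2 (0.45 log units; beyond the scatter), shows that swapping the aminophenyl group for the dichlorophenyl group weakened growth inhibition by a modest but real margin.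

Compound 3 `COc1ccc(C(=O)/C=C/c2cc(-c3cc(OC)c(OC)c(OC)c3)n[nH]2)cc1` takes a further step at the same position: 4-methoxyphenyl in place of 3,4-dichlorophenyl on a carbonyl carbon. Within the data shown here, the one measured step bears on it only loosely, since the group that enters is neither of the two already compared; a methoxy group carries a hydrogen-bond acceptor, which the dichlorophenyl group lacks, so the number is expected to move back toward that of compound 1. For compound 3 a modest drop in this assay is expected, a 1.9-fold lower number from compound 2 to compound 3 (0.28 log units; within the scatter), giving an estimate of 5500 nM with a likely range from 2200 nM to 14000 nM.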

Compound 3, concentration for 50% growth inhibition: 2700 nM
The estimate for compound 3 lay 2.0-fold (0.31 log units) above the measured number; measured number inside the range.
By their numbers in this assay, from the lowest: compounds 3 and 1 (each within the scatter of the next); then compound 2.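

Compound 3 shows that the group on the carbonyl carbon can recover growth inhibition lost with 3,4-dichlorophenyl: in this assay, 4-methoxyphenyl in its place gives a 3.9-fold lower number from compound 2 to compound 3 (0.59 log units; beyond the scatter). Methoxy in place of amino on the aromatic carbon gives a 1.4-fold lower number from compound 1 to compound 3 (0.15 log units; within the scatter), so the 4-aminophenyl and 4-methoxyphenyl groups cannot be told apart here, and of the three groups only 3,4-dichlorophenyl stands apart, with the higher number. Nothing available explains why these groups differ in this way.

The compounds shown leave open whether a ring carrying a single chlorine would follow the 3,4-dichlorophenyl group or the other two. As far as these compounds go, it is also open whether a hydroxy group or a longer ethoxy chain could take the place of methoxy without a change in the number.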